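Chloro on the diaminoquinazoline of the thiazolyl lead

The source may report more compounds than this note shows. Statements on the series, on what has been measured and on what is new or still open speak of the compounds shown alone.

Three measured members share one core, differing only in the group on the benzimidazole carbon. Compound 1 `Cc1cc2nc(-c3nccs3)n(-c3ccc4c(N)nc(N)nc4c3)c2cc1C` carries a 1,3-thiazol-2-yl group and in an assay on isolated protein for inhibition of Dihydrofolate reductase (Homo sapiens), read by spectrophotometry, using NADPH, with a stated time of 10 min (a lower number here means a stronger inhibitor, a higher number a weaker inhibitor), compound 1 gives 93 nM, the lowest number of the three. Compound 2 `Cc1cc2nc(-c3ccco3)n(-c3ccc4c(N)nc(N)nc4c3)c2cc1C` gives 943 nM and compound 3 `Cc1cc2nc(C3CCCO3)n(-c3ccc4c(N)nc(N)nc4c3)c2cc1C` gives 749 nM; the steps of a 10-fold higher number from compound 1 to compound 2 (1.01 log units; beyond the scatter) and an 8.1-fold higher number from compound 1 to compound 3 (0.91 log units; beyond the scatter) are both beyond the scatter, while a 1.3-fold lower number from compound 2 to compound 3 (0.10 log units; within the scatter) is not.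

Compound 4 `Cc1cc2nc(-c3nccs3)n(-c3cc4nc(N)nc(N)c4cc3Cl)c2cc1C` keeps the thiazolyl group and differs from compound 1 elsewhere: chloro in place of hydrogen on an aromatic carbon, placed on an aromatic carbon of a six-membered aromatic ring of carbon only, part of a fused system of two rings, ortho to a large group, meta to a fused ring and para to a fused ring. Going by the values given here, none of the measured steps touches this part of the core; all three concern the benzimidazole substituent. Nothing in the series therefore points to a change beyond the scatter, and the expectation rests on compound 1 alone. The step of no change at the digits printed from compound 1 to compound 4 (within the scatter) is expected to stay within the scatter, and compound 4 is estimated at 93 nM with a range of 30 nM to 300 nM.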

Compound 4, inhibition constant: 7.6 nM
For compound 4 the middle estimate is 12-fold (1.09 log units) above the measured one; measured number below the stated range.
By their numbers in this assay, from the lowest: compound 4; then compound 1; then compounds 3 and 2 (each within the scatter of the next).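

Chloro in place of hydrogen on this aromatic carbon, ortho to a large group, gives (a 12-fold lower number from compound 1 to compound 4 (1.09 log units; beyond the scatter)) in this assay, so the number responds to a change away from the thiazolyl group as well. The earlier steps shown here concerned only the group that replaces 1,3-thiazol-2-yl, and both steps away from that group raised the number, whereas this single added chlorine atom lowers it. No measurement shown bears on why chloro has this effect.

Whether the lower number is specific to chloro remains open, since fluoro, bromo, methyl and methoxy on the same carbon are not among the compounds shown. On these data alone, it is also open whether chloro would lower the number to a similar extent with the furan-2-yl group of compound 2 or the oxolan-2-yl group of compound 3.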